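Swapping a dichlorophenyl pattern on a urea-linked anilinoquinazoline

The source may report more compounds than this note shows. Statements on the series, on what has been measured and on what is new or still open speak of the compounds shown alone.

Measured compounds:
- compound 1, `COc1cc(Nc2ncnc3c(NC(=O)Nc4cccc(Oc5ccccc5)c4)cccc23)cc(OC)c1`: 14000 nM
- compound 2, `COc1cc(Nc2ncnc3c(NC(=O)Nc4cccc(Cl)c4Cl)cccc23)cc(OC)c1`: 63.2 nM
- compound 3, `COc1cc(Nc2ncnc3c(NC(=O)Nc4cc(C(F)(F)F)cc(C(F)(F)F)c4)cccc23)cc(OC)c1`: 467 nM

All three share one core and differ only in the aryl group on the urea. In a functional assay on RT-112 cells (Homo sapiens) for antiproliferative activity, read by MTT assay, with a stated time of 72 h (on this read-out lower numbers stand for stronger inhibition of growth and higher numbers for weaker inhibition of growth), compound 2 gives the lowest number of the three; its gap to compound 3 and its much larger gap to compound 1 both lie beyond the usual scatter. The unmeasured compound 4, `COc1cc(Nc2ncnc3c(NC(=O)Nc4ccc(Cl)cc4Cl)cccc23)cc(OC)c1`, keeps the same atoms but joins them differently: 2,4-dichlorophenyl in place of 2,3-dichlorophenyl on an amide-type nitrogen. Among the compounds with values here, no measured pair shows this change, so its effect is uncertain. A modest weakening is expected, as a step of a 2.4-fold higher number from compound 2 to compound 4 (0.38 log units; beyond the scatter), since no measured neighbour suggests a gain. Compound 4 is therefore expected to give about 150 nM, within a range from 40 nM to 600 nM.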

Compound 4, concentration for 50% growth inhibition: 3060 nM
For compound 4 the middle estimate is 20-fold (1.31 log units) below the measured one; measured number outside the range, above it.
By their numbers in this assay, from the lowest: compound 2; then compound 3; then compound 4; then compound 1.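

In this assay, 2,4-dichlorophenyl in place of 2,3-dichlorophenyl on an amide-type nitrogen gives a 48-fold higher number from compound 2 to compound 4 (1.69 log units; beyond the scatter), even though the two compounds have the same atoms. At this place on the urea, then, how the two chlorines are arranged on the ring matters greatly, not just that they are present. Nothing given here bears on why the number rises. On these data alone, it remains open whether a nitrile or an amine in place of one chlorine would keep the number as low as that of compound 2.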